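The source may hold more compounds than are shown below. What is called first, only, known or untested is meant among the compounds shown, and "the series" means these compounds.

Working notes, cytotoxicity across the shared core, read in an ADME assay on BCBL1 cells (Homo sapiens) for cytotoxicity, with a stated time of 7 days; a lower number here means that less compound is tolerated, a higher number that more compound is tolerated. Compound 1 `CCCCSc1nc(N)nc2c1ncn2/C=C1/CC1(CO)CO` gives only a limit of the assay, > 20000 nM. Compound 2 `CC(C)CSc1nc(N)nc2c1ncn2/C=C1/CC1(CO)CO` likewise gives only a limit, > 20000 nM. Compound 3 `Nc1nc(NCc2ccccc2)c2ncn(/C=C3/CC3(CO)CO)c2n1` gives a number, 19900 nM. Compound 2 thus stands at the limit, where most of the values sit (the limit of > 20000 nM in this assay, at which 2 of the 3 values shown sit). The step that the two limits leave unreadable from compound 1 to compound 2 has no readable size; the steps of a number no higher from compound 2 to compound 3 (the limit leaves the size open) and a number no higher from compound 1 to compound 3 (the limit leaves the size open) give only a bound, not a size, and the number for compound 3 is anyway within the scatter of that limit. Compound 4 `C=CCOc1nc(N)nc2c1ncn2/C=C1/CC1(CO)CO` carries allyloxy in place of isobutylsulfanyl on an aromatic carbon. Within the data shown here, no measured step between a sulfanyl group and an oxy group on that aromatic carbon exists, and every change recorded so far leaves the read-out at or about the limit, so no step beyond the scatter is expected from compound 2 to compound 4, a number no higher from compound 2 to compound 4 (the limit leaves the size open). Compound 4 is therefore expected near 20000 nM, within 10000 nM to 40000 nM, most likely again reported only as a limit.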

Compound 4, half-maximal cytotoxic concentration: > 20000 nM
Compound 4: a limit, no number (the forecaster's own chance of this, stated with the estimate: 80%); the middle value sits exactly at the limit.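

In this assay compound 4 gives > 20000 nM, which is a limit of the assay and not a number. Allyloxy in place of benzylamino gives a number no lower from compound 3 to compound 4 (the limit leaves the size open) on this aromatic carbon. On this aromatic carbon, next to the ring nitrogen, allyloxy is the first group shown that is bound through oxygen and the first with a double bond outside aromatic rings, and the read-out still ends at the limit, as it does with butylsulfanyl and isobutylsulfanyl. None of the new steps has a readable size, so the change from sulfanyl to oxy has no measurable effect here, and the result adds only one more compound to the cluster: the limit of > 20000 nM in this assay, at which 3 of the 4 values shown sit.

On these data alone, how far compound 1, compound 2 and compound 4 lie beyond the limit remains open. Also open, as far as these compounds go, is whether a carboxylic acid, a tertiary amine or a chain longer than butylsulfanyl on this carbon would give a number.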